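The source may report more compounds than this note shows. Statements on the series, on what has been measured and on what is new or still open speak of the compounds shown alone.

Measured in a functional assay on HBL-100 cells (Homo sapiens) for antiproliferative activity, read by luminescence and CellTiter-Glo, with a stated time of 48 h; on this read-out higher numbers stand for weaker inhibition and lower numbers for stronger inhibition:
Compound 1 `O=C1C=CC[C@H](/C=C/c2ccc([N+](=O)[O-])cc2)O1`: 6700 nM
Compound 2 `O=C1C=CC[C@@H](/C=C/c2ccc([N+](=O)[O-])cc2)O1`: > 100000 nM (a limit)

Compound 2 has no numerical value, only the limit > 100000 nM. Going by the values given here, the single measured step, an at least 14-fold higher number from compound 1 to compound 2 (1.17 log units; beyond the scatter), is large and beyond the scatter, and it accompanies (the fact that compounds 1 and 2 differ only in the configuration as drawn). Compound 3 `O=C1C=CC[C@@H](/C=C/c2ccc(F)cc2)O1` keeps the configuration drawn for compound 2 and carries fluoro in place of nitro on an aromatic carbon. Among the compounds with values here, no measured step covers this exchange, so the configuration is the only guide, and little change is expected in this assay. The expected step is an at least 1.2-fold lower number from compound 2 to compound 3 (0.09 log units; that floor lies within the scatter). The estimate for compound 3 is 80000 nM, with an expected range of 20000 nM to 200000 nM.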

Compound 3, half-maximal inhibitory concentration: > 100000 nM
Compound 3 was reported as a limit (the forecaster's own chance of this, stated with the estimate: 55%); middle value at least 1.2-fold (0.09 log units) from the limit.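

Compound 2 and compound 3 are both reported only as limits in this assay, and the step between them cannot be read. The compounds shown leave open what fluoro in place of nitro does in this assay.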